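Oxazolidinone side-chain variants: cytotoxicity outlook for compound 4

The compounds below may be only part of what the source reports. "The series", "measured", "known", "first", "only" and "open" are said of these compounds alone.

Measured compounds:
compound 1 `O=C1O[C@@H](CN2CCCCC2)CN1c1ccc(-n2cc(-c3ccccn3)cn2)c(F)c1`: > 400 ug/mL
compound 2 `COC(=O)CC1CCN(C[C@H]2CN(c3ccc(-n4cc(-c5ccccn5)cn4)c(F)c3)C(=O)O2)CC1`: > 400 ug/mL
compound 3 `O=C1O[C@@H](Cn2ccnn2)CN1c1ccc(-n2cc(-c3ccccn3)cn2)c(F)c1`: 49 ug/mL

In an ADME assay on L02 cells (Homo sapiens) for cytotoxicity, read by MTT assay, with a stated time of 48 h (on this read-out higher numbers stand for weaker inhibition and lower numbers for stronger inhibition), compound 1 gives only a limit, > 400 ug/mL. Compound 2 also reaches only a limit in this assay, > 400 ug/mL. Compound 3 gives a number, 49 ug/mL. Compound 1 thus stands at the limit of this assay, where (the limit of > 400 ug/mL in this assay, at which 2 of the 3 values shown sit); its standing against compound 2 is a step that the two limits leave unreadable from compound 1 to compound 2. Going by the values given here, the one readable change from compound 1 is an at least 8.1-fold lower number from compound 1 to compound 3 (0.91 log units; beyond the scatter), matched by an at least 8.1-fold lower number from compound 2 to compound 3 (0.91 log units; beyond the scatter), so exchanging piperidin-1-yl on the chain carbon for a small ring lowered the number in both cases.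

Compound 4 `CCNC(=O)NC[C@H]1CN(c2ccc(-n3cc(-c4ccccn4)cn3)c(F)c2)C(=O)O1` differs from compound 1 by (ethylcarbamoyl)amino in place of piperidin-1-yl on a saturated chain carbon bound to a saturated ring carbon. Again piperidin-1-yl leaves, but the entering (ethylcarbamoyl)amino is an open chain rather than a ring, so the step to compound 3 is only a partial guide. Compound 4 is expected to give about 250 ug/mL in this assay, within 60 ug/mL to 400 ug/mL. This estimate amounts to an expected step of an at least 1.6-fold lower number from compound 1 to compound 4 (0.20 log units; that floor lies within the scatter), with a fair chance that the limit is reached again.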

Compound 4, half-maximal inhibitory concentration: > 400 ug/mL
Compound 4 gave a limit, no number (the forecaster's own chance of this, stated with the estimate: 50%); middle value at least 1.6-fold (0.20 log units) away from the limit.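

In this assay compound 4 reaches only a limit, so an open chain on this saturated chain carbon sits at the same limit as the piperidin-1-yl groups: the limit of > 400 ug/mL in this assay, at which 3 of the 4 values shown sit.

Exchanging 1H-1,2,3-triazol-1-yl for (ethylcarbamoyl)amino gives an at least 8.1-fold higher number from compound 3 to compound 4 (0.91 log units; beyond the scatter), so among the groups shown only 1H-1,2,3-triazol-1-yl stands apart, and the loss of piperidin-1-yl alone does not bring a lower number. The steps from compound 1 and from compound 2 to compound 4 join two limits and cannot be read.

From the compounds shown here alone, whether the lower number of compound 3 belongs to 1H-1,2,3-triazol-1-yl alone or would recur with 1H-imidazol-1-yl or a primary amine on the same chain carbon stays open. Going by these compounds, how compound 1, compound 2 and compound 4 rank among one another also stays open.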